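Moving the trifluoromethyl group around the benzamide ring

This account rests on a few compounds, and the source may have more. Where it says the series, first, only, none or still open, it means among the compounds named here.

Measured compounds:
- compound 1 `COC(=O)c1scc(-c2ccc(NC(=O)c3cccc(C(F)(F)F)c3)cc2)c1OC`: 19300 nM
- compound 2 `COC(=O)c1scc(-c2ccc(NC(=O)c3cccc(OC(F)(F)F)c3)cc2)c1OC`: 16600 nM
- compound 3 `COC(=O)c1scc(-c2ccc(NC(=O)c3ccc(C#N)nc3)cc2)c1OC`: "not determined" (no result reported)

All three compounds share one core and differ only in the acyl part of the amide. In a functional assay on HeLa cells (Homo sapiens) for antiproliferative activity, read by MTT assay, with a stated time of 24 h (on this read-out lower numbers stand for stronger inhibition and higher numbers for weaker inhibition), compound 1 gives 19300 nM, and compound 2 gives 16600 nM; the two are separated only by a 1.2-fold lower number from compound 1 to compound 2 (0.07 log units; within the scatter), so on the numbers shown compound 1 and compound 2 cannot be told apart. Compound 3 carries a nitrile on a pyridine ring in this part of the molecule, but in this assay compound 3 gives "not determined" (no result reported), so it adds nothing to the comparison.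

Compound 4 `COC(=O)c1scc(-c2ccc(NC(=O)c3ccc(C(F)(F)F)cc3)cc2)c1OC` is the unmeasured partner of compound 1. The change is 4-(trifluoromethyl)phenyl in place of 3-(trifluoromethyl)phenyl on a carbonyl carbon. Among the measured compounds shown here, the only measured step, the swap of trifluoromethyl for trifluoromethoxy, exchanges groups rather than moving one, so no step directly addresses this change; the one step available was within the scatter. Compound 4 is therefore expected to land close to compound 1, with a step of a 1.0-fold lower number from compound 1 to compound 4 (0.01 log units; within the scatter) in this assay. The estimate for compound 4 is 19000 nM, with a range from 9000 nM to 40000 nM.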

Compound 4, half-maximal inhibitory concentration: 14400 nM
Beside the measured number, compound 4's estimate is 1.3-fold (0.12 log units) above it; measured number inside the range.
By their numbers in this assay, from the lowest: compounds 4, 2 and 1 (each within the scatter of the next).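

Moving the trifluoromethyl group, so that 4-(trifluoromethyl)phenyl stands in place of 3-(trifluoromethyl)phenyl on the carbonyl carbon, gives in this assay a 1.3-fold lower number from compound 1 to compound 4 (0.13 log units; within the scatter). The earlier comparison had only exchanged one group for another, whereas this step keeps the same atoms and changes only how they are joined, and it shows that this rearrangement of the acyl part does not separate the two compounds on the numbers reported. No accompanying measurement bears on the reason for this result.

From the compounds shown here alone, whether an amine or a carboxylic acid carried by the phenyl ring in place of the trifluoromethyl group would produce a step beyond the scatter remains open, and so does the behaviour of a 4-(trifluoromethoxy)phenyl group on the same carbonyl carbon. The compounds shown also leave open whether any change outside the acyl part, such as a carboxylic acid in place of the methyl ester on the shared core, would move the number in this assay.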